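Swapping Chloro for Bromo on the Shared Core

The source may hold more compounds than are shown below. What is called first, only, known or untested is meant among the compounds shown, and "the series" means these compounds.

Compound 3 `Cc1ccc2[nH]c(=O)c(-c3nc4cc(Cl)ccc4[nH]3)cc2c1` is measured in a functional assay on HepG2 cells (Homo sapiens) for cytotoxicity, read by MTT assay, with a stated time of 48 h (on this read-out higher numbers stand for weaker inhibition and lower numbers for stronger inhibition), where it gives 26600 nM. Compound 1 `O=c1[nH]c2ccccc2cc1-c1nc2cc(Br)ccc2[nH]1` gives 10800 nM in this assay, so of the two numbers shown, compound 3 carries the higher one. Compound 2 `Cc1ccc2[nH]c(=O)c(-c3nc4cc(F)ccc4[nH]3)cc2c1` reaches only a limit of this assay, at > 100000 nM. Going by the values given here, the only measured step is an at least 3.7-fold lower number from compound 2 to compound 3 (0.57 log units; beyond the scatter), and its size is bounded because one end sits at the limit of > 100000 nM in this assay, at which 1 of the 3 values shown sits. Compound 4 `Cc1ccc2[nH]c(=O)c(-c3nc4cc(Br)ccc4[nH]3)cc2c1` differs from compound 3 in one place: bromo in place of chloro on an aromatic carbon. Because the step of an at least 3.7-fold lower number from compound 2 to compound 3 (0.57 log units; beyond the scatter) also put one halogen in place of another and lowered the number, a further but smaller drop is expected here, a 1.8-fold lower number from compound 3 to compound 4 (0.25 log units; within the scatter). Compound 4 is therefore estimated at 15000 nM, within a range from 6000 nM to 40000 nM.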

Compound 4, half-maximal inhibitory concentration: > 100000 nM
Compound 4: only a limit was reported; the forecaster's own chance of this, stated with the estimate: 5%; middle value at least 6.6-fold (0.82 log units) away from the limit.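

With bromo in place of chloro at this position, the number goes up rather than further down, with an at least 3.7-fold higher number from compound 3 to compound 4 (0.57 log units; beyond the scatter) in this assay, so the order of the halogens is not a simple trend. The methyl on the shared core also matters among the bromo compounds, with an at least 9.2-fold higher number from compound 1 to compound 4 (0.96 log units; beyond the scatter). The step from compound 2 to compound 4 cannot be read, because each of these compounds gives a limit rather than a number: the limit of > 100000 nM in this assay, at which 2 of the 4 values shown sit.

On these data alone, how far past the limit compound 4 lies remains open. So does how an amine or a methoxy group would read on this aromatic carbon.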